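This account rests on a few compounds, and the source may have more. Where it says the series, first, only, none or still open, it means among the compounds named here.

Two compounds have been measured in a functional assay on Jurkat cells (Homo sapiens) for antiproliferative activity, read by MTT assay, with a stated time of 6 days; on this read-out higher numbers stand for weaker inhibition and lower numbers for stronger inhibition:

Compound 1, `CC(=O)O[C@@H]1C=CC(=O)O[C@@H]1[C@@H](COC(=O)c1ccc([N+](=O)[O-])cc1)OC(C)=O`, gives 7450 nM.
Compound 2, `O=C1C=C[C@@H](OCc2ccccc2)[C@@H]([C@@H](COC(=O)/C=C/c2ccccc2)OCc2ccccc2)O1`, gives 4960 nM.

Compound 2 holds the lowest of the two numbers in this assay, and the nearest number is that of compound 1; the gap between the two lies within the scatter of repeated measurements, so the two values cannot be told apart.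

Compound 3, `COc1ccc(/C=C/C(=O)OC[C@@H](OCc2ccccc2)[C@H]2OC(=O)C=C[C@H]2OCc2ccccc2)cc1`, has not yet been measured in this assay. Compared with compound 2 the change is methoxy in place of hydrogen on an aromatic carbon. For the measured compounds named here, no pair of measured compounds shows a step of this kind, so nothing in the measured data speaks for a shift in either direction. Going by the values given here, with a change this small and no comparable step to lean on, the expected step in this assay is a 1.1-fold lower number from compound 2 to compound 3 (0.04 log units; within the scatter), which stays within the scatter. On that basis compound 3 is estimated at 4500 nM, with a range from 1800 nM to 11000 nM.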

Compound 3, half-maximal inhibitory concentration: 10300 nM
Compound 3: the middle estimate sits 2.3-fold (0.36 log units) below what was measured, and the stated range covers the measured number.
By their numbers in this assay, from the lowest: compounds 2, 1 and 3 (each within the scatter of the next, the first and the last beyond it).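

In this assay, for the compounds shown here, replacing phenyl with 4-methoxyphenyl gives a 2.1-fold higher number from compound 2 to compound 3 (0.32 log units; beyond the scatter), the first step that can be read at all. It shows that this aromatic carbon, para to a large group, is not indifferent to substitution: adding methoxy, with its 2 heavy atoms and no ring, moves the read-out modestly towards weaker inhibition, so this change brings no gain here. With only one substituent at one position, however, this is a single observation rather than a trend, and no measured property is available to account for it.

Going by these compounds, it remains open whether a different group at the same carbon, such as a hydroxyl group, a fluorine atom or an amine, would shift the number in the same direction, or whether the shift follows from methoxy alone. Also open, on these data alone, is whether methoxy on another carbon of this ring, or on the other aromatic rings of compound 2, would give a step of similar size and direction.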